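The source may hold more compounds than are shown below. What is called first, only, known or untested is meant among the compounds shown, and "the series" means these compounds.

Of the compounds shown here, three that share one core have been tested in a functional assay (aorta) with Rattus norvegicus as the target; a higher number here means a weaker inhibitor, a lower number a stronger inhibitor. Compound 1 `CCO/C(O)=C1\C(COCCNC(=O)NC)=NC(C)=C(C(=O)OC)C1c1ccccc1Cl` gives 3.16 nM, the lowest of the three numbers. Compound 2 `CCO/C(O)=C1\C(COCCNC(=O)NCC(N)=O)=NC(C)=C(C(=O)OC)C1c1ccccc1Cl` gives 20 nM, and compound 3 `CCO/C(O)=C1\C(COCCN(C)S(N)(=O)=O)=NC(C)=C(C(=O)OC)C1c1ccccc1Cl` gives 25.1 nM. Both steps away from compound 1 made the inhibitor weaker: a 6.3-fold higher number from compound 1 to compound 2 (0.80 log units; beyond the scatter) and a 7.9-fold higher number from compound 1 to compound 3 (0.90 log units; beyond the scatter). Compound 2 and compound 3 lie within the scatter of each other: a 1.3-fold higher number from compound 2 to compound 3 (0.10 log units; within the scatter).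

Compound 4 `CCO/C(O)=C1\C(COCCN(C)/C(=N/C)NC#N)=NC(C)=C(C(=O)OC)C1c1ccccc1Cl` has not yet been measured in this assay. It differs from compound 1 in one place: a group of 8 heavy atoms (4 carbon, 4 nitrogen; no ring) in place of a group of 5 heavy atoms (2 carbon, 2 nitrogen, 1 oxygen; no ring), on a saturated chain carbon, two bonds along the chain from an oxygen on a saturated carbon. The two measured steps that bear on this one both altered the (methylcarbamoyl)amino group of compound 1 or the chain attached to it, and in each case the number rose by a modest amount, so neither change kept the strength of compound 1. The change to compound 4 is a substitution at that same place, and a modest rise in this assay is therefore expected, though nothing in the three measured compounds fixes its exact size. The step expected from compound 1 to compound 4 is a 5.1-fold higher number from compound 1 to compound 4 (0.70 log units; beyond the scatter). Compound 4 is estimated at 16 nM, with a range from 4 nM to 63 nM.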

Compound 4, half-maximal inhibitory concentration: 25.1 nM
Compound 4: the middle estimate sits 1.6-fold (0.20 log units) below what was measured; the range from low to high includes it.
By their numbers in this assay, from the lowest: compound 1; then compounds 2, 3 and 4 (each within the scatter of the next).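

Replacing the (methylcarbamoyl)amino group with a group of 8 heavy atoms that carries a nitrile also weakens the inhibitor in this assay, a 7.9-fold higher number from compound 1 to compound 4 (0.90 log units; beyond the scatter), so this third replacement at the same place on the chain does not keep the strength of compound 1 either. The new group also cannot be told apart from the two earlier replacements, with no change at the digits printed from compound 3 to compound 4 (within the scatter) and a 1.3-fold higher number from compound 2 to compound 4 (0.10 log units; within the scatter). Groups as different in their atoms as the sulfur-containing one of compound 3 and the nitrile-bearing one of compound 4 therefore sit together, leaving compound 1 alone at the low end of these four, and no supporting information is available to explain this result.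

It remains open which part of the (methylcarbamoyl)amino group matters, since every replacement shown changes more than one feature at once. A urea with an ethyl group in place of the methyl, or a simple acetamide or a plain amine at this place, would show how much of this group can be altered before the number rises.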